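This account rests on a few compounds, and the source may have more. Where it says the series, first, only, none or still open, it means among the compounds named here.

Measured so far in a functional assay on KB cells (Homo sapiens) for antiproliferative activity, read by sulforhodamine B assay, tested at 100 ug/mL; a higher number here means more inhibition at the concentration tested (going by the name of the read-out), a lower number less inhibition:
compound 1 `Cc1ccc(NS(=O)(=O)C2CCCCC2=O)c(C)c1` gives 7.97%
compound 2 `O=C1CCCCC1S(=O)(=O)Nc1ccc(Cl)cc1C(F)(F)F` gives 11.2%
compound 3 `O=C1CCCCC1S(=O)(=O)Nc1ccc(Cl)cc1` gives -3.83%

Compound 3 stands lowest of the three numbers in this assay; the nearest is compound 1, higher and beyond the scatter, and the furthest is compound 2, also higher and beyond the scatter. Going by the values given here, the only single-change step measured, a number 15 percentage points lower from compound 2 to compound 3 (beyond the scatter), concerns a hydrogen in place of trifluoromethyl and does not involve the group that changes here.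

Compound 4 `Cc1ccc(NS(=O)(=O)C2CCCCC2=O)cc1` differs from compound 3 in one place: methyl in place of chloro on an aromatic carbon. Among the compounds with values here, no measured step bears directly on a methyl in place of chloro, so the expectation rests on neighbouring numbers. Compound 1, which carries a methyl on the ring together with a second methyl, gives 7.97% in this assay, above compound 3 beyond the scatter; compound 2 shows that a substituted ring can sit higher still, but with a different group. On these few numbers a small step upward at most is expected, probably within the scatter, giving an expected a number 6.8 percentage points higher from compound 3 to compound 4 (within the scatter). Compound 4 is therefore estimated at 3% in this assay, with an expected range from -10% to 15%.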

Compound 4, a percentage reported as inhibition, at one concentration (the size of the read-out at that concentration, not a potency): -22.2%
The estimate for compound 4 lay 25.2 percentage points above the measured number; the measured number lies below the stated range.
By their numbers in this assay, from the lowest: compound 4; then compound 3; then compounds 1 and 2 (each within the scatter of the next).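

In this assay, the ring position para to a large group is sensitive to the exchange of chloro for methyl, a swap of one heavy atom for one heavy atom: the change gives a number 18.4 percentage points lower from compound 3 to compound 4 (beyond the scatter), so the two groups are not interchangeable here. Going by these compounds alone, compound 4 also supplies the largest step so far, a number 30.2 percentage points lower from compound 1 to compound 4 (beyond the scatter), which runs in the same direction as a number 15 percentage points lower from compound 2 to compound 3 (beyond the scatter); in both of these pairs, the compound with hydrogen in place of the extra ring substituent has the lower number, although the groups involved differ. No measurement available here bears on what lies behind these steps.

The compounds shown leave open whether the order of chloro over methyl at this position holds when the extra ring substituent is present, since no pair compares the two groups with that substituent in place of hydrogen. They also leave open how a methoxy group, an amine or a carboxylic acid at the same position would compare with chloro and methyl, and what an unsubstituted carbon there would give.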